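A few compounds are considered here, and "the series" means these few. Any claim that something is new, unique, unknown or untested is made for them only; others in the source may bear on it.

Measured in a functional assay on A2780 cells (Homo sapiens) for inhibition, read by sulforhodamine B assay, with a stated time of 72 h; on this read-out lower numbers stand for stronger inhibition and higher numbers for weaker inhibition:
- compound 1 `O=C(NCc1ccc(S(=O)(=O)c2ccccc2)cc1)c1cc2ccncc2s1`: 14 nM
- compound 2 `O=C(NCc1ccc(S(=O)(=O)c2ccccc2)cc1)c1ccc2nccn2c1`: 13 nM

For the measured compounds named here, compound 2 stands level with compound 1, the only measured step being a 1.1-fold lower number from compound 1 to compound 2 (0.03 log units; within the scatter). Compound 3 `O=C(NCc1ccc(S(=O)(=O)c2ccccc2)cc1)c1cn2ccnc2cn1` departs from compound 2 by a group of 9 heavy atoms (6 carbon, 3 nitrogen; one five-membered aromatic ring with 2 hetero atoms, one six-membered aromatic ring with 2 hetero atoms) in place of a group of 9 heavy atoms (7 carbon, 2 nitrogen; one five-membered aromatic ring with 2 hetero atoms, one six-membered aromatic ring with 1 hetero atom), on a carbonyl carbon. That measured exchange on the carbonyl carbon moved nothing beyond the scatter, but neither measured compound carries a six-membered aromatic ring with 2 hetero atoms, so it offers only weak guidance. A moderate shift towards weaker inhibition is expected, though no change remains possible. The expected size is a 2.3-fold higher number from compound 2 to compound 3 (0.36 log units; beyond the scatter). Compound 3 is estimated at 30 nM, with an expected range of 8 nM to 150 nM.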

Compound 3, half-maximal inhibitory concentration: > 10000 nM
Compound 3: no number, only a limit (the forecaster's own chance of this, stated with the estimate: 3%); at least 330-fold (2.52 log units) between middle value and limit.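

In this assay compound 3 gives only a limit, not a number: the limit of > 10000 nM in this assay, at which 1 of the 3 values shown sits.

This position on the carbonyl carbon is therefore not indifferent to the exchange, since the group with a six-membered aromatic ring with 2 hetero atoms brings an at least 760-fold higher number from compound 2 to compound 3 (2.88 log units; beyond the scatter) and likewise an at least 710-fold higher number from compound 1 to compound 3 (2.85 log units; beyond the scatter). The two earlier groups had stood level, so the sharp sensitivity appears only with this third group.

The compounds shown leave open how large the step truly is, and whether an amine or a methoxy group on the entering group would restore inhibition.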